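From methyl back to an aryl group

The source may report more compounds than this note shows. Statements on the series, on what has been measured and on what is new or still open speak of the compounds shown alone.

For the measured compounds named here, in a functional assay (brain) for inhibition, with Rattus norvegicus as the target (on this read-out lower numbers stand for stronger inhibition and higher numbers for weaker inhibition), compound 2 `Cc1cc2c(N3CCCC3)nc(N3CCCC3)nc2n1C` gives 1000 nM, the lower of the two numbers so far, and compound 1 `Cn1c(-c2ccccc2)cc2c(N3CCCC3)nc(N3CCCC3)nc21` gives 5000 nM. Compound 3 `COc1ccc(-c2cc3c(N4CCCC4)nc(N4CCCC4)nc3n2C)cc1` carries 4-methoxyphenyl in place of methyl on an aromatic carbon. Going by the values given here, the only guide is a 5.0-fold lower number from compound 1 to compound 2 (0.70 log units; beyond the scatter), a modest step beyond the scatter, with methyl in place of phenyl. Read in reverse, it points to an expected higher number of similar size in this assay. Among the compounds with values here, no measurement yet shows what the methoxy adds. The expected step is a 4.0-fold higher number from compound 2 to compound 3 (0.60 log units; beyond the scatter). For compound 3 the estimate is 4000 nM, with an expected range from 1300 nM to 12000 nM.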

Compound 3, half-maximal inhibitory concentration: 1000 nM
Estimate against measurement, compound 3: 4.0-fold (0.60 log units) above; measured number outside the range, below it.
By their numbers in this assay, from the lowest: compounds 2 and 3 (each within the scatter of the next); then compound 1.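

In this assay this position accepts 4-methoxyphenyl in place of methyl, with no change at the digits printed from compound 2 to compound 3 (within the scatter), so an aryl group here does not of itself raise the number. Methoxy in place of hydrogen on the aromatic carbon of the phenyl gives a 5.0-fold lower number from compound 1 to compound 3 (0.70 log units; beyond the scatter), so the two aryl groups do not read alike. Nothing measured accounts for this difference.

Open, as far as these compounds go, is whether a hydroxy group, an amine or a longer alkoxy chain in place of methoxy keeps the number of compound 3.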